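A few compounds are considered here, and "the series" means these few. Any claim that something is new, unique, unknown or untested is made for them only; others in the source may bear on it.

In an in vitro ADME assay on microsomes from liver (Homo sapiens) for metabolic stability, read by LC-MS (a lower number here means that the compound disappears faster, a higher number that the compound lasts longer), compound 1 `N#Cc1ccccc1Cn1c(N2CCC[C@@H](N)C2)ncc(-c2cc[nH]c2)c1=O` gives 1.02 h. Compound 2 `N#Cc1ccccc1Cn1c(N2CCC[C@@H](N)C2)ncc(C#CCO)c1=O` gives > 3.33 h, a limit and not a number, and so stands at the limit of > 3.33 h in this assay, at which 1 of the 2 values shown sits. Among the measured compounds shown here, the one measured step is an at least 3.2-fold higher number from compound 1 to compound 2 (0.51 log units; beyond the scatter), with 3-hydroxyprop-1-yn-1-yl in place of 1H-pyrrol-3-yl. Compound 3 `N#Cc1ccccc1Cn1c(N2CCC[C@@H](N)C2)ncc(/C=C/c2ccc(F)cc2)c1=O` carries 2-(4-fluorophenyl)ethenyl in place of 3-hydroxyprop-1-yn-1-yl on an aromatic carbon. A ring-bearing group returns to this carbon, as in compound 1 at 1.02 h, so a fall of at least modest size is expected in this assay. The expected step is an at least 3.3-fold lower number from compound 2 to compound 3 (0.52 log units; beyond the scatter). Compound 3 is estimated at 1 h, with an expected range of 0.4 h to 2.8 h.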

Compound 3, half-life: 3.1 h
The estimate for compound 3 lay 3.1-fold (0.49 log units) below the measured number; measured number outside the range, above it.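

The change from 1H-pyrrol-3-yl to 2-(4-fluorophenyl)ethenyl gives a 3.0-fold higher number from compound 1 to compound 3 (0.48 log units; beyond the scatter) in this assay, so a ring on this carbon does not by itself bring the low number of compound 1. The other step reads an at least 1.0-fold lower number from compound 2 to compound 3 (0.03 log units; that floor lies within the scatter), which sets no order between these two groups. Compound 2 remains a limit and not a number: the limit of > 3.33 h in this assay, at which 1 of the 3 values shown sits.

The compounds shown do not separate the fluorine from the ring or the ethenyl link. Going by these compounds, what a plain phenyl on that link, or a chain ending in an amine, gives at this carbon stays open.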